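Shortening the Aryl Chain Further in a Lactone Series

The source may report more compounds than this note shows. Statements on the series, on what has been measured and on what is new or still open speak of the compounds shown alone.

Compound 1 `O=C(CCCCCCCCCCc1ccccc1)CC(=O)N[C@H]1CCOC1=O` gives 14000 nM in a functional assay on NCI-H630 cells (Homo sapiens) for cytotoxicity, read by sulforhodamine B assay, with a stated time of 5 days; a higher number here means a weaker inhibitor, a lower number a stronger inhibitor.
Compound 2 `O=C(CCCCCCCCc1ccccc1)CC(=O)N[C@H]1CCOC1=O` gives 10000 nM in this assay.
Compound 3 `O=C(CCCCCCCc1ccccc1)CC(=O)N[C@H]1CCOC1=O` gives 10000 nM in this assay.

The three measured compounds share one core and differ only in how far the phenyl ring sits from the chain. Compound 3 stands level with compound 2 at the digits shown, and together they have the lowest of the three numbers; its distance from compound 1 is a 1.4-fold lower number from compound 1 to compound 3 (0.15 log units; within the scatter), so all three compounds sit within the usual scatter of one another.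

Compound 4 `O=C(CCCCCc1ccccc1)CC(=O)N[C@H]1CCOC1=O` takes the same kind of change one stage further: phenyl in place of phenethyl on a saturated chain carbon, five bonds along the chain from a carbonyl carbon.

Within the data shown here, three measured steps bear on this. The same kind of swap, phenyl in place of phenethyl, appears in a 1.4-fold lower number from compound 1 to compound 2 (0.15 log units; within the scatter). The neighbouring swaps give no change at the digits printed from compound 2 to compound 3 (within the scatter) and a 1.4-fold lower number from compound 1 to compound 3 (0.15 log units; within the scatter). None of these crosses the scatter, so the bridge length between ring and chain has so far left this assay essentially untouched. A step of no size beyond the scatter is therefore expected for no change at the digits printed from compound 3 to compound 4 (within the scatter).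

Compound 4 is expected to give about 10000 nM in this assay, with a likely range from 5000 nM to 20000 nM.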

Compound 4, half-maximal inhibitory concentration: 24000 nM
For compound 4 the middle estimate is 2.4-fold (0.38 log units) below the measured one; the measured number lies above the stated range.
By their numbers in this assay, from the lowest: compounds 2, 3, 1 and 4 (each within the scatter of the next, the first and the last beyond it).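

Phenyl in place of phenethyl on a saturated chain carbon, five bonds along the chain from a carbonyl carbon, is the first change in this set to move the number in this assay beyond the scatter, with a 2.4-fold higher number from compound 3 to compound 4 (0.38 log units; beyond the scatter). The change therefore does not carry one fixed effect along the series, and what it does depends on where along the chain it is made: the same change on two cores in this assay, a 1.4-fold lower number (0.15 log units; within the scatter) from compound 1 to compound 2 and a 2.4-fold higher number (0.38 log units; beyond the scatter) from compound 3 to compound 4, 3.4-fold (0.53 log units) apart, beyond the scatter of two such steps. Among these compounds, the chain length looked silent among the earlier compounds, but here the step is real, though modest, and it points towards a weaker inhibitor.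

The compounds shown leave open whether a still shorter chain would push the number higher in this assay, or whether this single step marks no lasting trend. They also leave open what an amine or a carboxylic acid in place of the phenyl would do at this chain length.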